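The compounds below may be only part of what the source reports. "The series", "measured", "known", "first", "only" and "open" are said of these compounds alone.

Compound 1 `O=C(O)CCc1cn(CC(=O)NCc2ccccc2)nn1` and compound 2 `O=C(Cn1cc(C(=O)OCc2ccccc2)nn1)NCc1ccccc1` share one core and differ only in the group it carries. In an ADME assay on cells (spleen, Mus musculus, strain C57BL/6) for inhibition, read by flow cytometry and propidium iodide staining, with a stated time of 24 h, at 37 degrees C (a higher number here means that more compound is needed for the effect, a lower number that less compound is needed), compound 1 gives 1420 uM, and compound 2 gives 720 uM; these two numbers lie within the usual scatter of each other, so neither stands apart. Compound 3 `O=C(Cn1cc(-c2cccc(F)c2)nn1)NCc1ccccc1` differs from compound 1 in one place: 3-fluorophenyl in place of 2-carboxyethyl on an aromatic carbon. Within the data shown here, no measured pair shows this exchange of 2-carboxyethyl for 3-fluorophenyl, so the step is uncertain. A moderate move toward a lower number in this assay is expected, a 4.1-fold lower number from compound 1 to compound 3 (0.61 log units; beyond the scatter). Compound 3 is estimated at 350 uM, within a range from 100 uM to 1200 uM.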

Compound 3, concentration for half-maximal effect: "non-toxic" (no number reported)
The entry for compound 3 holds no number; no gap can be computed for the estimate.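

In this assay, among these compounds, compound 3 carries the entry "non-toxic" (no number reported) with no number, so no step from compound 1 to compound 3 can be read. Nothing shown here explains that entry. From the compounds shown here alone, how exchanging 2-carboxyethyl for 3-fluorophenyl shifts the number remains open.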